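This account rests on a few compounds, and the source may have more. Where it says the series, first, only, none or still open, it means among the compounds named here.

Measured so far in a physicochemical assay for solubility, read by nephelometry; on this read-out lower numbers stand for lower solubility and higher numbers for higher solubility:
Compound 1 `CC1(C)C(=O)N(c2ccc(SC(F)(F)F)cc2)C(=O)N1Cc1ccnc(N2CCCCC2)c1` gives a limit of the assay, < 0.024 ug/mL.
Compound 2 `CN1CCN(c2cc(CN3C(=O)N(c4ccc(SC(F)(F)F)cc4)C(=O)C3(C)C)ccn2)CC1` gives 0.159 ug/mL.
Compound 3 `CNC(=O)c1cc(CN2C(=O)N(c3ccc(SC(F)(F)F)cc3)C(=O)C2(C)C)ccn1` gives a limit of the assay, < 0.023 ug/mL.

Among the measured compounds shown here, compound 2 therefore stands as the only compound of the three with a number in this assay; the other two sit at limits (the limit of < 0.023 ug/mL in this assay, at which 1 of the 3 values shown sits, (the limit of < 0.024 ug/mL in this assay, at which 1 of the 3 values shown sits)). Compound 4 `CCc1cc(CN2C(=O)N(c3ccc(SC(F)(F)F)cc3)C(=O)C2(C)C)ccn1` differs from compound 2 in one place: ethyl in place of 4-methylpiperazin-1-yl on an aromatic carbon.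

For the measured compounds named here, two measured steps bear on this change, since each of them replaces or introduces the 4-methylpiperazin-1-yl group on the same aromatic carbon. There was an at least 6.6-fold higher number from compound 1 to compound 2 (0.82 log units; beyond the scatter), and there was an at least 6.9-fold lower number from compound 2 to compound 3 (0.83 log units; beyond the scatter). Both steps away from the 4-methylpiperazin-1-yl compound end at a limit, whether the partner group is piperidin-1-yl or methylcarbamoyl. An ethyl group in that place is expected to behave in the same way, so an 8.0-fold lower number from compound 2 to compound 4 (0.90 log units; beyond the scatter) is expected, a step beyond the scatter and downward. Compound 4 is accordingly estimated at 0.02 ug/mL in this assay, with a range from 0.005 ug/mL to 0.08 ug/mL, and most likely it will be reported only as a limit.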

Compound 4, solubility: < 0.022 ug/mL
Compound 4: only a limit was reported (the forecaster's own chance of this, stated with the estimate: 70%); the middle value does not contradict the limit.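

On this aromatic carbon next to the ring nitrogen, in this assay, ethyl in place of 4-methylpiperazin-1-yl gave an at least 7.2-fold lower number from compound 2 to compound 4 (0.85 log units; beyond the scatter), so a small group with no ring and no hetero atoms does not keep the number that compound 2 gives. Compound 4 gives only a limit of the assay: the limit of < 0.022 ug/mL in this assay, at which 1 of the 4 values shown sits. Among the four groups shown here, only 4-methylpiperazin-1-yl gives a number, while piperidin-1-yl, methylcarbamoyl and ethyl all end at limits, and the steps among compounds 1, 3 and 4 cannot be read.

From the compounds shown here alone, it remains open how far compounds 1, 3 and 4 lie from one another beneath their limits. Whether a dimethylamino group, a piperazin-1-yl group without its methyl, or a carboxylic acid on this carbon would also give a number is not settled by these compounds.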